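The source may hold more compounds than are shown below. What is called first, only, known or untested is meant among the compounds shown, and "the series" means these compounds.

Measured compounds:
compound 1, `O=C(CCCCC(S)CCS)Nc1ccccc1`, 25.4%
compound 2, `O=C(CCCCC(S)CCS)Nc1ccc(Cl)cc1`, 40.9%
compound 3, `O=C(CCCCC(S)CCS)Nc1ccccn1`, 11.7%

All three were tested in a functional assay on NCI-H460 cells (Homo sapiens) for inhibition, read by MTT assay, with a stated time of 24 h, tested at 100 ug/mL; a higher number here means more inhibition of growth at the concentration tested, a lower number less inhibition of growth. Compound 1 carries a phenyl group on its amide-type nitrogen; compound 2 differs from it by one change, (chloro in place of hydrogen on an aromatic carbon), and that step gave a number 15.5 percentage points higher from compound 1 to compound 2 (beyond the scatter). Compound 3 differs from compound 1 in the ring on the amide-type nitrogen, (pyridin-2-yl in place of phenyl on an amide-type nitrogen), and that step gave a number 13.7 percentage points lower from compound 1 to compound 3 (beyond the scatter), leaving compound 3 with the lowest of the three values.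

Compound 4, `O=C(CCCCC(S)CCS)Nc1ccc(Cl)cn1`, has not yet been measured. It stands to compound 3 as compound 2 stands to compound 1: the change is chloro in place of hydrogen on an aromatic carbon. For the measured compounds named here, it is the same kind of change as the one from compound 1 to compound 2, not the same one: there the chloro entered on a six-membered aromatic ring of carbon only, here it enters on a six-membered aromatic ring with 1 nitrogen, two atoms from the ring nitrogen, while in both cases the place is para to a large group.

Going by the values given here, with only one earlier example of this change to go on, the expectation for compound 4 is a step of roughly the same size as a number 15.5 percentage points higher from compound 1 to compound 2 (beyond the scatter), that is a number 14.3 percentage points higher from compound 3 to compound 4 (beyond the scatter) from compound 3, with wide uncertainty because the ring around the new chloro is a different one. Compound 4 is therefore estimated at 26%, with a plausible range from 12% to 40%.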

Compound 4, percent growth inhibition at one concentration: 55.8%
The estimate for compound 4 lay 29.8 percentage points below the measured number, and the stated range ends below it.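

In this assay, putting chloro in place of hydrogen on the pyridin-2-yl compound gave a number 44.1 percentage points higher from compound 3 to compound 4 (beyond the scatter), a large step. For the compounds shown here, the change raised the number on both cores, but its size did not carry over from one core to the other, so the step measured on the phenyl pair would have been a poor guide to the size of the step on the pyridin-2-yl pair: the same change on two cores in this assay, a number 15.5 percentage points higher (beyond the scatter) from compound 1 to compound 2 and a number 44.1 percentage points higher (beyond the scatter) from compound 3 to compound 4, 28.6 percentage points apart, beyond the scatter of two such steps This does not show why the two steps differ, and with only two pairs it gives no rule for what the same change would do on a third ring, nor does a reading at a single concentration show how the compounds would compare across a range of concentrations.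

The compounds shown leave open whether a fluoro, bromo or methoxy group in the place taken by the chloro would give a similar rise on either core. They also leave open how much of the growth inhibition depends on the thiol groups of the side chain, for instance whether a carboxylic acid or a shorter chain in that part of the molecule would keep it.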